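Amine substituent changes in the aminoquinoline ether series

The compounds below may be only part of what the source reports. "The series", "measured", "known", "first", "only" and "open" are said of these compounds alone.

Compound 1 `CC(CNCC1CC1)Oc1cccc2ccc(N)nc12` carries a cyclopropylmethyl group on the amine nitrogen. For the measured compounds named here, in a functional assay on IMR-32 cells with melanin-concentrating hormone receptor 1 (Homo sapiens) as the target, read by fluorescence (a lower number here means a stronger inhibitor, a higher number a weaker inhibitor), compound 1 gives 460 nM, the highest of the two numbers measured so far; its nearest neighbour is compound 2 `CC(CNC1CCCC1)Oc1cccc2ccc(N)nc12`, which in this assay gives 30 nM. Going by the values given here, the one step measured, a 15-fold lower number from compound 1 to compound 2 (1.19 log units; beyond the scatter), exchanges the whole cyclopropylmethyl group for a cyclopentyl ring bound directly to the amine nitrogen.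

Compound 3 `CC(CNCc1ccoc1)Oc1cccc2ccc(N)nc12` is the next change to this position: furan-3-yl in place of cyclopropyl on a saturated chain carbon bound to an amine nitrogen. Compared with the measured step, this change keeps the single saturated chain carbon between the ring and the amine nitrogen, so the step from compound 1 to compound 2 bears on it only as a sign that this position tolerates a larger ring with a strongly lower number; no measured compound carries an aromatic ring here. The expected change is therefore smaller and uncertain in direction: the estimate is a 1.5-fold lower number from compound 1 to compound 3 (0.19 log units; within the scatter). For compound 3 the expected value in this assay is 300 nM, within a range of 80 nM to 1200 nM.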

Compound 3, half-maximal inhibitory concentration: 100 nM
Estimate against measurement, compound 3: 3.0-fold (0.48 log units) above, and the stated range covers the measured number.
By their numbers in this assay, from the lowest: compound 2; then compound 3; then compound 1.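

In this assay the step to furan-3-yl gives a 4.6-fold lower number from compound 1 to compound 3 (0.66 log units; beyond the scatter) on the saturated chain carbon bound to an amine nitrogen, so this position accepts an aromatic ring, and a lower number here does not require a ring bound directly to the amine nitrogen. The cyclopentyl group of compound 2 still stands ahead of the (furan-3-yl)methyl group, with a 3.3-fold higher number from compound 2 to compound 3 (0.52 log units; beyond the scatter) in the same assay, and all three compounds now lie beyond the scatter of one another. No supporting data explain either step, and this single change does not separate ring size, aromatic character and the ring oxygen.

Phenyl or thiophen-3-yl on the same saturated chain carbon would show whether the ring oxygen of furan-3-yl matters or whether any five- or six-membered aromatic ring serves equally well. Cyclopentylmethyl on the amine nitrogen would separate the effect of the saturated ring from that of the chain carbon, and so show whether the advantage of compound 2 belongs to the ring itself or to its direct attachment to the amine nitrogen.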